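A few compounds are considered here, and "the series" means these few. Any claim that something is new, unique, unknown or untested is made for them only; others in the source may bear on it.

Compound 1 `CC[C@@H](Nc1nc(NCc2ccccn2)c2ncn(C(C)C)c2n1)C(C)(C)O` gives 34000 nM in a functional assay on A2780 cells (Homo sapiens) for inhibition, read by sulforhodamine B assay, with a stated time of 96 h; a lower number here means a stronger inhibitor of growth, a higher number a weaker inhibitor of growth.
Compound 2 `CC[C@@H](Nc1nc(NCc2ccccn2)c2ncn(C(C)C)c2n1)C(C)O` gives 15000 nM in this assay.
Compound 3 `CC[C@H](Nc1nc(NCc2ccccn2)c2ncn(C(C)C)c2n1)C(C)O` gives 10000 nM in this assay.

Compound 1 and compound 2 share a core and differ in one place: methyl in place of hydrogen on a saturated chain carbon bound to an oxygen on a saturated carbon and two saturated chain carbons. In this assay that change produced a 2.3-fold higher number from compound 2 to compound 1 (0.36 log units; beyond the scatter). The cores of compound 2 and compound 3 differ only in the drawn configuration: the two compounds have the same atoms and bonds; at least one stereo element is drawn with a configuration in one of them and without one in the other: 1 of 2 stereo elements differ; a stereocentre at a saturated chain carbon is drawn R in compound 2 and S in compound 3. Between these two the difference in this assay is a 1.5-fold lower number from compound 2 to compound 3 (0.18 log units; within the scatter), so nothing can be said about which of the two is the stronger inhibitor of growth. Compound 3 and compound 1 are separated by a 3.4-fold lower number from compound 1 to compound 3 (0.53 log units; beyond the scatter).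

Compound 4 `CC[C@H](Nc1nc(NCc2ccccn2)c2ncn(C(C)C)c2n1)C(C)(C)O` has not yet been tested. Relative to compound 3 it carries methyl in place of hydrogen on a saturated chain carbon bound to an oxygen on a saturated carbon and two saturated chain carbons. For the measured compounds named here, the surroundings of the changed carbon are described in the same words for both pairs, so this is the same change as the one from compound 2 to compound 1. Because that earlier change gave a 2.3-fold higher number from compound 2 to compound 1 (0.36 log units; beyond the scatter), the step from compound 3 to compound 4 is expected to be of similar size, about a 2.3-fold higher number from compound 3 to compound 4 (0.36 log units; beyond the scatter). Compound 4 is therefore expected to give roughly 23000 nM, most likely between 11000 nM and 50000 nM.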

Compound 4, concentration for 50% growth inhibition: 19000 nM
Compound 4: middle estimate off by 1.2-fold (0.08 log units), on the high side; measured number inside the range.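

Placing methyl on this carbon of the compound 3 core gives a step (a 1.9-fold higher number from compound 3 to compound 4 (0.28 log units; within the scatter)) that matches the earlier one on the other core: the same change on two cores in this assay, a 2.3-fold higher number (0.36 log units; beyond the scatter) from compound 2 to compound 1 and a 1.9-fold higher number (0.28 log units; within the scatter) from compound 3 to compound 4, 1.2-fold (0.08 log units) apart, within the scatter of two such steps. Within these two pairs, then, the change carries over at a similar size, but the step on the compound 3 core cannot on its own be told from scatter, and two pairs do not show that the match would hold on any other core. The other two new steps (a 1.3-fold higher number from compound 2 to compound 4 (0.10 log units; within the scatter) and a 1.8-fold lower number from compound 1 to compound 4 (0.25 log units; within the scatter)) are also within the scatter, so no order can be given for compound 1 and compound 4, the mirror-drawn pair at this stereocentre: the fact that compounds 1 and 4 differ only in the configuration as drawn.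

The compounds shown carry only hydrogen or methyl on this carbon, so it remains open whether an ethyl group or a longer chain would continue the same trend. Going by these compounds, it also remains open how an amine or a methyl ether in place of the hydroxyl would behave in this assay.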